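A few compounds are considered here, and "the series" means these few. Any claim that something is new, unique, unknown or untested is made for them only; others in the source may bear on it.

Measured compounds:
Compound 1, `COc1ccc(CNCCCNS(=O)(=O)c2cc(C(F)(F)F)cc(C(F)(F)F)c2)cc1OC`, in a functional assay on Capan-2 cells (Homo sapiens) for inhibition, read by MTT assay, with a stated time of 72 h (a lower number here means a stronger inhibitor of growth, a higher number a weaker inhibitor of growth), gives 15000 nM.
Compound 2, `O=S(=O)(NCCCNCc1ccccc1)c1cc(C(F)(F)F)cc(C(F)(F)F)c1`, in this assay gives 14000 nM.

For the measured compounds named here, on the numbers so far compound 2 stands alongside compound 1: the two values lie within the scatter of each other, and the only measured step, a 1.1-fold lower number from compound 1 to compound 2 (0.03 log units; within the scatter), shows no change in growth inhibition. That step puts phenyl in place of 3,4-dimethoxyphenyl on a saturated chain carbon bound to an amine nitrogen.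

Compound 3, `COc1cccc(CNCCCNS(=O)(=O)c2cc(C(F)(F)F)cc(C(F)(F)F)c2)c1`, is not yet measured in this assay. Its difference from compound 2 is methoxy in place of hydrogen on an aromatic carbon. Going by the values given here, the one measured step that bears on this is the step from compound 1 to compound 2, which removes both methoxy groups of compound 1 from the same ring and stays within the scatter; compound 3 carries one of those methoxy groups again. Nothing here points to a step beyond the scatter in either direction.

Compound 3 is therefore expected near 14000 nM, with a range of 7000 nM to 28000 nM. The expected step is no change at the digits printed from compound 2 to compound 3 (within the scatter), within the scatter.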

Compound 3, concentration for 50% growth inhibition: 6400 nM
Compound 3: the middle estimate sits 2.2-fold (0.34 log units) above what was measured; the whole stated range lies above it.
By their numbers in this assay, from the lowest: compound 3; then compounds 2 and 1 (each within the scatter of the next).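

In this assay, for the compounds shown here, phenyl to 3-methoxyphenyl gives the first change beyond the scatter, a 2.2-fold lower number from compound 2 to compound 3 (0.34 log units; beyond the scatter), though it is modest. Methoxy on this ring therefore does not act as a uniform change: taking the second methoxy group away gives a 2.3-fold lower number from compound 1 to compound 3 (0.37 log units; beyond the scatter), while the earlier step with both groups removed, a 1.1-fold lower number from compound 1 to compound 2 (0.03 log units; within the scatter), stays within the scatter, so the single-methoxy compound 3 stands apart from both the unsubstituted and the 3,4-dimethoxyphenyl compounds. No measurement available here accounts for this difference between one methoxy group and two.

The compounds shown leave open whether the step belongs to methoxy itself or would also appear with hydroxy, ethoxy or fluorine on that aromatic carbon, or with methoxy on another carbon of the ring. They also leave open whether the same step would hold with a longer chain joining the amine and the sulfonamide.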